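Cyclic Amine to Isobutoxy on the Pyridine of a Urea Series

The source may hold more compounds than are shown below. What is called first, only, known or untested is meant among the compounds shown, and "the series" means these compounds.

Measured compounds:
compound 1, `O=C(NCc1ccc(C(F)(F)F)nc1N1CCCCC1)Nc1cccc2[nH]c(=O)ccc12`: 0.75 nM
compound 2, `O=C(NCc1ccc(C(F)(F)F)nc1N1CCCC1)Nc1cccc2[nH]c(=O)ccc12`: 0.94 nM
compound 3, `CCCN(CCC)c1nc(C(F)(F)F)ccc1CNC(=O)Nc1cccc2[nH]c(=O)ccc12`: 5.21 nM

In an assay on HEK cells for antagonist activity at transient receptor potential cation channel subfamily V member 1 (Homo sapiens), read by FLIPR (on this read-out lower numbers stand for stronger inhibition and higher numbers for weaker inhibition), compound 1 gives the lowest of the three numbers. Its nearest neighbour is compound 2, with a 1.3-fold higher number from compound 1 to compound 2 (0.10 log units; within the scatter), so the two cannot be told apart. Compound 3 sits furthest away, with a 6.9-fold higher number from compound 1 to compound 3 (0.84 log units; beyond the scatter) and, from compound 2, a 5.5-fold higher number from compound 2 to compound 3 (0.74 log units; beyond the scatter). Both cyclic amines thus give close numbers, while the open-chain dipropylamino costs a modest amount.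

Compound 4, `CC(C)COc1nc(C(F)(F)F)ccc1CNC(=O)Nc1cccc2[nH]c(=O)ccc12`, has not yet been measured. It differs from compound 1 as follows: isobutoxy in place of piperidin-1-yl on an aromatic carbon. Among the compounds with values here, the step that bears most on it is the move to an open-chain group in compound 3, a 6.9-fold higher number from compound 1 to compound 3 (0.84 log units; beyond the scatter), although isobutoxy is smaller than dipropylamino and carries oxygen rather than nitrogen, so no measured step matches it exactly. A modest weakening beyond the scatter is therefore expected, a 5.3-fold higher number from compound 1 to compound 4 (0.73 log units; beyond the scatter). For compound 4 the estimate in this assay is 4 nM, with a range from 1.2 nM to 15 nM.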

Compound 4, half-maximal inhibitory concentration: 2.6 nM
Compound 4: middle estimate off by 1.5-fold (0.19 log units), on the high side, within the range that was stated.
By their numbers in this assay, from the lowest: compounds 1 and 2 (each within the scatter of the next); then compounds 4 and 3 (each within the scatter of the next).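

In this assay, isobutoxy on the aromatic carbon next to the ring nitrogen gives a 3.5-fold higher number from compound 1 to compound 4 (0.54 log units; beyond the scatter) and a 2.8-fold higher number from compound 2 to compound 4 (0.44 log units; beyond the scatter), so an open-chain group joined through oxygen also falls short of both cyclic amines. Against the other open-chain group, it gives a 2.0-fold lower number from compound 3 to compound 4 (0.30 log units; within the scatter), which leaves the two unresolved and places both open-chain groups apart from the cyclic amines across these four compounds. Nothing available explains this separation or shows what underlies it.

The compounds shown do not separate the presence of a ring from the identity of the joining atom, since both cyclic groups are joined through nitrogen. Cyclopentyloxy, a ring joined through oxygen, and isobutylamino, an open chain joined through nitrogen, would pull those two features apart.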